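The compounds below may be only part of what the source reports. "The series", "measured", "known", "first", "only" and "open" are said of these compounds alone.

Measured compounds:
- Compound 1, `CC(C)CCN1CCC[C@H](Cn2c(CN(C)[C@H]3CCCc4cccnc43)nc3ccccc32)C1`: 2300 nM
- Compound 2, `CN1CCC[C@@H](Cn2c(CN(C)[C@@H]3CCCc4cccnc43)nc3ccccc32)C1`: 2800 nM
- Compound 3, `CN(Cc1nc2ccccc2n1CC1CNC1)C1CCCc2cccnc21`: 15000 nM

Three compounds share a core and have been examined in an ADME assay on HOS cells (Homo sapiens) for cytotoxicity; on this read-out lower numbers stand for higher toxicity in this test and higher numbers for lower toxicity in this test. Compound 2 stands second highest of the three numbers. Its nearest neighbour is compound 1, whose value lies within the scatter of that of compound 2, so no order can be read between them. The furthest is compound 3, whose number is higher than that of compound 2 by a gap beyond the scatter.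

The step of interest leads from compound 2 to compound 4, `CN1CCC[C@H](Cn2c(CN(C)[C@@H]3CCCc4cccnc43)nc3ccccc32)C1`, which has not yet been measured in this assay. The two compounds differ as follows: the two compounds have the same atoms and bonds and differ only in configuration as drawn: 1 of 2 stereo elements differ; a stereocentre at a saturated ring carbon is drawn R in compound 2 and S in compound 4

For the measured compounds named here, no measured pair in this set differs in one place alone, so no step of this kind has been observed. On that basis the expected change from compound 2 is none beyond the scatter: a stereochemical flip with no change in atoms or bonds gives no grounds for predicting a shift in either direction. Compound 4 is therefore estimated at 3000 nM in this assay, with a range from 1200 nM to 8000 nM, meaning an expected step of a 1.1-fold higher number from compound 2 to compound 4 (0.03 log units; within the scatter).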

Compound 4, half-maximal cytotoxic concentration: 3600 nM
Beside the measured number, compound 4's estimate is 1.2-fold (0.08 log units) below it; the range from low to high includes it.
By their numbers in this assay, from the lowest: compounds 1, 2 and 4 (each within the scatter of the next); then compound 3.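

In this assay the set now holds its first step in one place alone, a 1.3-fold higher number from compound 2 to compound 4 (0.11 log units; within the scatter), and this step stays within the scatter. Inverting this stereocentre at a saturated ring carbon, with the other stereo element held as drawn, therefore produces no readable shift for this pair of compounds, something the earlier compounds, none of which differed in one place alone, could not show. The comparison isolates configuration at this one position: the fact that compounds 2 and 4 differ only in the configuration as drawn

The compounds shown offer no step at the other stereo element, so its influence on this read-out remains open. Also open, on these data alone, is whether inverting this stereocentre would remain as inconsequential in compounds carrying a carboxylic acid or a hydroxyl group on the shared core.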